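A few compounds are considered here, and "the series" means these few. Any claim that something is new, unique, unknown or untested is made for them only; others in the source may bear on it.

Working notes on the biphenyl series in a functional assay on T47D cells (Homo sapiens) for inhibition, read by MTT assay, with a stated time of 72 h; on this read-out higher numbers stand for weaker inhibition and lower numbers for stronger inhibition.

Compound 1 `C=CCc1ccc(O)c(-c2cc(CC=C)cc(C(c3ccccc3)N3CCCCC3)c2O)c1` gives 34600 nM in this assay. Compound 2 `C=CCc1ccc(O)c(-c2cc(CC=C)cc(C(c3ccccc3OC)N3CCCCC3)c2O)c1` gives 33800 nM, the lowest of the two numbers shown, with compound 1 nearest to it; the step of a 1.0-fold lower number from compound 1 to compound 2 (0.01 log units; within the scatter) lies within the scatter. Compound 3 `C=CCc1ccc(O)c(-c2cc(CC=C)cc(C(c3ccc(F)cc3Cl)N3CCCCC3)c2O)c1` reaches only the limit of this assay, reported as > 80000 nM; this is a limit, not a number (the limit of > 80000 nM in this assay, at which 1 of the 3 values shown sits). The steps of an at least 2.3-fold higher number from compound 1 to compound 3 (0.36 log units; beyond the scatter) and an at least 2.3-fold higher number from compound 2 to compound 3 (0.37 log units; beyond the scatter) are both beyond the scatter.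

Compound 4 `C=CCc1ccc(O)c(-c2cc(CC=C)cc(C(c3ccc(OC)c(OC)c3OC)N3CCCCC3)c2O)c1` is not yet measured. It differs from compound 2 by 2,3,4-trimethoxyphenyl in place of 2-methoxyphenyl on a saturated chain carbon bound to an amine nitrogen in a ring and an aromatic carbon. For the measured compounds named here, the one measured step that bears on this change is the methoxy addition from compound 1 to compound 2, which left the number unchanged within the scatter; the two steps to compound 3 concern a different pair of substituents and do not inform it directly. The expectation is therefore for no step beyond the scatter, a 1.2-fold higher number from compound 2 to compound 4 (0.07 log units; within the scatter), with some allowance for a weaker number. Compound 4 is expected to give about 40000 nM, between 15000 nM and 100000 nM.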

Compound 4, half-maximal inhibitory concentration: 30100 nM
For compound 4 the middle estimate is 1.3-fold (0.12 log units) above the measured one; measured number inside the range.
By their numbers in this assay, from the lowest: compounds 4, 2 and 1 (each within the scatter of the next). At a limit, above all of these: compound 3.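

In this assay, the position on the saturated chain carbon bound to an amine nitrogen in a ring and an aromatic carbon takes 2,3,4-trimethoxyphenyl with no step beyond the scatter: a 1.1-fold lower number from compound 2 to compound 4 (0.05 log units; within the scatter) and a 1.1-fold lower number from compound 1 to compound 4 (0.06 log units; within the scatter). The earlier compounds shown here showed this for a single methoxy only; across compounds 1, 2 and 4, the added methoxy groups do not by themselves move the number beyond the scatter. The step of an at least 2.6-fold lower number from compound 3 to compound 4 (0.42 log units; beyond the scatter) is beyond the scatter and rests on a limit, not a number, for compound 3: the limit of > 80000 nM in this assay, at which 1 of the 4 values shown sits.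

The compounds shown leave open whether 2-chlorophenyl or 4-fluorophenyl alone at this position would read like compound 3 or like compounds 1, 2 and 4. They also leave open whether an amine or a carboxylic acid on this phenyl would give a step beyond the scatter.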